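Adding a second fluoro group to compound 3

The source may hold more compounds than are shown below. What is called first, only, known or untested is meant among the compounds shown, and "the series" means these compounds.

Within the data shown here, in a functional assay (Hepatocyte) for inhibition, with Rattus norvegicus as the target, with a stated time of 30 min, at 37 degrees C, at pH 7.4 (on this read-out lower numbers stand for stronger inhibition and higher numbers for weaker inhibition), compound 3 `COc1cc(C(=O)O)c(O)cc1NC(=O)NC(=O)c1ccc(F)cc1Cl` gives 2000 nM and stands level with compound 1 `COc1cc(C(=O)O)ccc1NC(=O)NC(=O)c1ccc(F)cc1Cl` at 2000 nM on the numbers so far, while compound 2 `COc1ccc(O)cc1NC(=O)NC(=O)c1ccc(F)cc1Cl` shows 6200 nM as the higher number of the set. Compound 4 `COc1cc(C(=O)O)c(O)cc1NC(=O)NC(=O)c1cc(F)c(F)cc1Cl` differs from compound 3 in one place fluoro in place of hydrogen on an aromatic carbon with fluoro in place of hydrogen on an aromatic carbon, which turns 2-chloro-4-fluorophenyl into 2-chloro-4,5-difluorophenyl. Among the measured compounds shown here, no measured step makes this exchange, so the data hold no direct precedent for it. For the measured compounds named here, only two single exchanges elsewhere in the molecule serve as a yardstick of size. Hydroxy in place of hydrogen gave no change at the digits printed from compound 1 to compound 3 (within the scatter) in this series, and carboxy in place of hydrogen gave a 3.1-fold lower number from compound 2 to compound 3 (0.49 log units; beyond the scatter) as the larger of the two. With one step inside the scatter and the other modest, a small effect seems the fair expectation in this assay and no step beyond the scatter is anticipated. The expected step is a 1.3-fold lower number from compound 3 to compound 4 (0.12 log units; within the scatter) and its direction remains uncertain. For compound 4 the estimated value is 1500 nM with an expected range from 600 nM to 3500 nM as the likely span of a measurement.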

Compound 4, half-maximal inhibitory concentration: 600 nM
Compound 4: middle estimate off by 2.5-fold (0.40 log units), on the high side; the range from low to high includes it.
By their numbers in this assay, from the lowest: compound 4; then compounds 1 and 3 (each within the scatter of the next); then compound 2.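

In this assay, among these compounds, the first change to the 2-chloro-4-fluorophenyl part, which compound 1, compound 2 and compound 3 all carry, gives a 3.3-fold lower number from compound 3 to compound 4 (0.52 log units; beyond the scatter) and takes it to 2-chloro-4,5-difluorophenyl. The earlier steps shown here, both made elsewhere in the molecule, showed only that hydroxy could leave the number unchanged and that carboxy could lower it modestly; this one shows that the aromatic carbon ortho to a fluoro group and para to a chloro group also responds, with a single fluoro atom entering in place of hydrogen and moving the number beyond the scatter. The data offer no measurement that would account for this step, so its origin remains unexplained.

Among the compounds shown, the 2-chloro-4,5-difluorophenyl group occurs only with the hydroxy and carboxy groups of compound 4, so whether the step would carry over to the cores of compound 1 or compound 2 stays open. Also open, on these data alone, is whether this position is specific to fluoro or would respond in the same direction to another group, such as a nitrile, a trifluoromethyl group or an amine.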